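Swapping the basic ring group on a bradykinin antagonist

This account rests on a few compounds, and the source may have more. Where it says the series, first, only, none or still open, it means among the compounds named here.

Compound 1 `COc1cc(C)c(S(=O)(=O)N(C)CCOCC(=O)N2CCN([C@@H]3CN4CCC3CC4)CC2)c(C)c1`: 8.1
Compound 2 `COc1cc(C)c(S(=O)(=O)N(C)CCOCC(=O)N2CCN(CC3CCN(C)CC3)CC2)c(C)c1`: 8.6
Compound 3 `CCN1CCC(N2CCN(C(=O)COCCN(C)S(=O)(=O)c3c(C)cc(OC)cc3C)CC2)CC1`: 8.8

In a functional assay on Umbilical vein for antagonist activity at B1 bradykinin receptor (Homo sapiens), using Schild analysis, with a stated time of 30 min (a lower number here means a less potent compound, a higher number a more potent compound, by a factor of ten per unit of this negative logarithm), compound 3 gives the highest of the three numbers; compound 2 sits within the scatter of it, while compound 1 lies clearly lower, the step of a number 0.70 log units higher from compound 1 to compound 3 (beyond the scatter). Compound 4 `COc1cc(C)c(S(=O)(=O)N(C)CCOCC(=O)N2CCN([C@H]3CN4CCC3CC4)CC2)c(C)c1` carries the change (a group of 8 heavy atoms (7 carbon, 1 nitrogen; 2 six-membered non-aromatic rings with 1 hetero atom each) in place of a group of 8 heavy atoms (7 carbon, 1 nitrogen; one six-membered non-aromatic ring with 1 hetero atom), on an amine nitrogen in a ring). For the measured compounds named here, the entering group is of the same kind as the one in compound 1, with one defined stereocentre, so the step from compound 1 to compound 3 runs the opposite way to this one. Its size was a number 0.70 log units higher from compound 1 to compound 3 (beyond the scatter); the step of a number 0.50 log units higher from compound 1 to compound 2 (beyond the scatter) points the same way. A drop of about that size is therefore expected, a number 0.60 log units lower from compound 3 to compound 4 (beyond the scatter), with the stereocentre unchecked. Compound 4 is estimated at 8.2, between 7.4 and 9.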

Compound 4, negative logarithm of the antagonist equilibrium constant: 7.2
For compound 4 the middle estimate is 1.00 log units above the measured one; measured number below the stated range.
By their numbers in this assay, from the lowest: compound 4; then compound 1; then compounds 2 and 3 (each within the scatter of the next).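

In this assay, for the compounds shown here, the group in compound 4 with its two six-membered rings costs far more than the earlier compounds suggested: a number 1.60 log units lower from compound 3 to compound 4 (beyond the scatter) and a number 1.40 log units lower from compound 2 to compound 4 (beyond the scatter) both exceed every earlier step. Atoms and bonds stay the same across the step, a number 0.90 log units lower from compound 1 to compound 4 (beyond the scatter), so the configuration at one saturated ring carbon alone separates the two: the fact that one of compounds 1 and 4 is drawn with a defined configuration and the other without, at the place where they differ

On these data alone, how an open-chain diethylaminoethyl group or a 1-propylpiperidin-4-yl group would compare on this amine nitrogen remains open.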